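Aryl swap on the urea nitrogen of compound 2

The compounds below may be only part of what the source reports. "The series", "measured", "known", "first", "only" and "open" are said of these compounds alone.

The series rests on a urea whose one nitrogen carries both a benzyl group and a triazole. In a functional assay on B16-F10 cells (Mus musculus) for cytotoxicity, read by MTT assay, with a stated time of 48 h (a lower number here means a stronger inhibitor, a higher number a weaker inhibitor), compound 1 `COc1cc(CN(C(=O)Nc2ccc(C#N)cc2)n2cnnc2)cc(OC)c1OC` gives 21000 nM. Compound 2 `COc1ccc(CN(C(=O)Nc2ccc(C#N)cc2)n2cnnc2)cc1OC` gives > 50000 nM in this assay, which is a limit of the assay rather than a number. Within the data shown here, the one measured step, an at least 2.3-fold higher number from compound 1 to compound 2 (0.37 log units; beyond the scatter), is therefore known only as a bound because of the limit of > 50000 nM in this assay, at which 1 of the 3 values shown sits. Compound 3 `O=C(NC1CCCCC1)N(Cc1ccccn1)n1cnnc1`, built on a different pattern with a cyclohexyl urea and a pyridinylmethyl group, gives 35800 nM in this assay.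

Compound 4 `COc1ccc(CN(C(=O)Nc2ccc(F)c(Cl)c2)n2cnnc2)cc1OC` differs from compound 2 by 3-chloro-4-fluorophenyl in place of 4-cyanophenyl on an amide-type nitrogen. Among the measured compounds shown here, no measured step touches the aryl group on the amide-type nitrogen; the step of an at least 2.3-fold higher number from compound 1 to compound 2 (0.37 log units; beyond the scatter) concerns the methoxy on the benzyl side and does not bear on this change. Compound 2 stands at the limit, the weakest position the numbers can show. For the measured compounds named here, with no precedent for the aryl swap, a step of a number no higher from compound 2 to compound 4 (the limit leaves the size open) is expected, not beyond the scatter. Compound 4 is estimated at 50000 nM, with a range from 15000 nM to 160000 nM.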

Compound 4, half-maximal inhibitory concentration: 20700 nM
Beside the measured number, compound 4's estimate is 2.4-fold (0.38 log units) above it; the range from low to high includes it.
By their numbers in this assay, from the lowest: compounds 4, 1 and 3 (each within the scatter of the next). At a limit, above all of these: compound 2.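

The aryl group on the amide-type nitrogen now has a measured step of its own, where the earlier step spoke only to the methoxy on the benzyl side. With the benzyl side unchanged, 3-chloro-4-fluorophenyl in place of 4-cyanophenyl gives, in this assay, an at least 2.4-fold lower number from compound 2 to compound 4 (0.38 log units; beyond the scatter), so this position can move a compound off the limit to a measured number. The size of the step remains a bound because of the limit: the limit of > 50000 nM in this assay, at which 1 of the 4 values shown sits.

The compounds shown do not separate the chlorine from the fluorine in the entering group. Also open, on these data alone, are how an aryl group carrying an amine or a carboxylic acid would read at this position, and whether the same swap holds with the benzyl group of compound 1.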